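A few compounds are considered here, and "the series" means these few. Any claim that something is new, unique, unknown or untested is made for them only; others in the source may bear on it.

Compound 1 `COc1ccccc1/C=C/c1nc(Nc2ccccc2Cl)c2ccccc2n1`: > 25000 nM (a limit)
Compound 2 `COc1ccccc1/C=C/c1nc(Nc2ccc(O)cc2)c2ccccc2n1`: > 25000 nM (a limit)
Compound 3 `COc1ccccc1/C=C/c1nc(Nc2cccc(O)c2)c2ccccc2n1`: 21700 nM

All three were tested in a functional assay on HCT-116 cells (Homo sapiens) for antiproliferative activity, with a stated time of 72 h; on this read-out lower numbers stand for stronger inhibition and higher numbers for weaker inhibition. Only compound 3 has an actual number, 21700 nM. Compound 1 and compound 2 both stop at the limit of > 25000 nM in this assay, at which 2 of the 3 values shown sit, so how far they lie from compound 3 is not known.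

The next structure is compound 4 `COc1ccc(/C=C/c2nc(Nc3cccc(O)c3)c3ccccc3n2)cc1`. Its change is 4-methoxyphenyl in place of 2-methoxyphenyl on a double-bonded chain carbon bound to a double-bonded chain carbon.

The measured steps offer only indirect guidance. One is an at least 1.1-fold lower number from compound 1 to compound 3 (0.06 log units; that floor lies within the scatter), and another is an at least 1.1-fold lower number from compound 2 to compound 3 (0.06 log units; that floor lies within the scatter). The third is a step that the two limits leave unreadable from compound 1 to compound 2. All three exchange the group on the nitrogen, and none alters the methoxyphenyl group, so none gives a direct size for this move. Changing the group on the nitrogen has so far produced no step shown to exceed the scatter, and that offers no reason to predict a large shift in this assay.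

A slightly lower number is expected, with no clear change beyond the scatter, and the estimated step is a 1.8-fold lower number from compound 3 to compound 4 (0.26 log units; within the scatter). For compound 4 the estimated value is 12000 nM, with an expected range from 2500 nM to 25000 nM.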

Compound 4, half-maximal inhibitory concentration: 22900 nM
Beside the measured number, compound 4's estimate is 1.9-fold (0.28 log units) below it; low and high end bracket the measured number.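

In this assay, the exchange of 2-methoxyphenyl for 4-methoxyphenyl gives a 1.1-fold higher number from compound 3 to compound 4 (0.02 log units; within the scatter), the first step shown that touches the methoxyphenyl group rather than the group on the nitrogen. It is also the first step read from two actual numbers, since every earlier step rested on at least one limit and gave a floor at best or no size at all. The two groups match in every count, and with 3-hydroxyphenyl on the nitrogen, this change of methoxy placement leaves the two compounds indistinguishable in this assay.

This pair says nothing about the same exchange with any other group on the nitrogen, and it does not show whether an amine, a carboxylic acid or a longer chain such as ethoxy in place of the methoxy group would shift the number beyond the scatter. Compound 1 and compound 2 offer only a limit, not a number, so they cannot serve as a base for such a comparison: the limit of > 25000 nM in this assay, at which 2 of the 4 values shown sit.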